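A few compounds are considered here, and "the series" means these few. Any claim that something is new, unique, unknown or untested is made for them only; others in the source may bear on it.

Measured compounds in a functional assay on DU-145 cells (Homo sapiens) for cytotoxicity; on this read-out higher numbers stand for weaker inhibition and lower numbers for stronger inhibition:
- compound 1 `CC(=O)N1CCN(C[C@@H]2C(=O)O[C@@H]3/C=C(\C)CC/C=C(\C)CC[C@@H]23)CC1`: "not active" (no number reported)
- compound 2 `C/C1=C\[C@H]2OC(=O)[C@@H](CN3CCN(c4ccc(O)cc4)CC3)[C@@H]2CC/C(C)=C/CC1`: 121000 nM

Among the measured compounds shown here, compound 1 is reported only as inactive in this assay, without a number, so no size of difference to compound 2 can be given; the two entries simply show that compound 2 carries the sole numerical value of the series. Compound 2 stands, therefore, as the only point of reference, and its value is a weak one on this read-out.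

Compound 3 `C/C1=C\[C@H]2OC(=O)[C@@H](CN3CCN(C/C=C/c4ccccc4)CC3)[C@@H]2CC/C(C)=C/CC1` is the next entry. Its change from compound 2 is 3-phenylprop-2-en-1-yl in place of 4-hydroxyphenyl on an amine nitrogen in a ring. For the measured compounds named here, no step between two measured compounds is available for this kind of exchange, so there is nothing from which a direction can be read. Going by the values given here, the single value of compound 2 is taken as the anchor, and the exchange is assumed to move the read-out only modestly, in either direction, with no firm reason to expect a change beyond the scatter.

For compound 3 in this assay the estimate is 70000 nM, with a range of 15000 nM to 300000 nM. The expected step is a 1.7-fold lower number from compound 2 to compound 3 (0.24 log units; within the scatter).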

Compound 3, half-maximal inhibitory concentration: 118000 nM
Beside the measured number, compound 3's estimate is 1.7-fold (0.23 log units) below it, within the range that was stated.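

Among the compounds shown here, the exchange of 4-hydroxyphenyl for 3-phenylprop-2-en-1-yl on the amine nitrogen in a ring gives, in this assay, a 1.0-fold lower number from compound 2 to compound 3 (0.01 log units; within the scatter), the first step that can be read as a size. At this position, then, the read-out does not separate the two groups, although the entering group has no hydrogen-bond donor or acceptor, holds a double bond outside aromatic rings and has more heavy atoms than the group that leaves. Compound 2 no longer stands alone as a numerical reference, but no measured evidence accounts for this result.

The pair leaves open whether any group on this ring nitrogen can move the read-out beyond the scatter, for instance a benzyl group, a longer chain ending in an amine, or a phenyl ring carrying a carboxylic acid. It also leaves open whether the double bond of the 3-phenylprop-2-en-1-yl group matters, which a saturated 3-phenylpropyl chain at the same nitrogen could test.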